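Replacing an Aromatic Amino Group with Ethyl

The source may report more compounds than this note shows. Statements on the series, on what has been measured and on what is new or still open speak of the compounds shown alone.

Compound 1 `Nc1cccc(Nc2nccc(-c3ccccn3)n2)c1` is the stronger of the two compounds measured in a functional assay for inhibition, with Homo sapiens as the target; on this read-out lower numbers stand for stronger inhibition and higher numbers for weaker inhibition. In this assay compound 1 gives 300 nM, whereas compound 2 `COc1ccccc1Nc1nccc(-c2cccnc2)n1` gives 9800 nM, a gap that lies beyond the usual scatter. Compound 3 `CCc1cccc(Nc2nccc(-c3ccccn3)n2)c1`, still unmeasured, differs from compound 1 in one place: ethyl in place of amino on an aromatic carbon. Among the measured compounds shown here, no measured pair shows this change, so its effect is open. A modest loss of potency is expected, the step of a 2.3-fold higher number from compound 1 to compound 3 (0.37 log units; beyond the scatter) being small and upward. In this assay compound 3 is estimated at 700 nM, within 150 nM to 3500 nM.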

Compound 3, half-maximal inhibitory concentration: 1400 nM
For compound 3 the middle estimate is 2.0-fold (0.30 log units) below the measured one, and the stated range covers the measured number.
By their numbers in this assay, from the lowest: compound 1; then compound 3; then compound 2.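

In this assay the step of a 4.7-fold higher number from compound 1 to compound 3 (0.67 log units; beyond the scatter) shows that this position on an aromatic carbon is sensitive to the change, though inhibition is not lost when ethyl replaces amino. The change removes the hydrogen-bond donor and acceptor of amino and adds a heavy atom, and this single pair cannot separate those differences. No measurement available here explains the step. As far as these compounds go, it remains open whether a hydroxyl or methylamino group in this place would restore the potency of compound 1. Whether methyl or a longer chain would differ from ethyl also stays unresolved.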